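The source may report more compounds than this note shows. Statements on the series, on what has been measured and on what is new or still open speak of the compounds shown alone.

Measured compounds in an assay on COS-7 cells for inhibition of patatin-like phospholipase domain-containing protein 2 (Mus musculus), tested at 200 uM; on this read-out higher numbers stand for more inhibition at the one concentration tested (going by the name of the read-out) and lower numbers for less inhibition:

compound 1, `CCOC(=O)c1ccc(-c2ccc(OCC)cc2)[nH]1`, 44%
compound 2, `CCOc1ccc(-c2cccc([N+](=O)[O-])c2)cc1`, 35%
compound 3, `CN(C)c1ccc(-c2cccc([N+](=O)[O-])c2)cc1`, 21%

Compound 3 gives the lowest of the three numbers in this assay. Its nearest neighbour is compound 2, which stands higher; compound 1 stands further above it. Among the compounds with values here, the one step between compounds that differ in a single place is a number 14 percentage points lower from compound 2 to compound 3 (beyond the scatter), a change that concerns the ethoxy-bearing ring, not the ring carrying the nitro group.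

Compound 4, `CCOC(=O)N(C)c1cccc(-c2ccc(N(C)C)cc2)c1`, is not yet measured. It differs from compound 3 by (ethoxycarbonyl)(methyl)amino in place of nitro on an aromatic carbon. Within the data shown here, no measured pair shows what replacing the nitro group does on this ring, so the step from compound 3 to compound 4 cannot be read off any measured step; the only guide is that compound 1, which carries an ester, sits at the top of the three numbers while the two nitro compounds sit lower. On that slender basis a small rise in this assay is expected, a number 6 percentage points higher from compound 3 to compound 4 (within the scatter), and the number remains uncertain.

Compound 4 is estimated at 27% in this assay, within a range from 8% to 48%.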

Compound 4, a percentage reported as inhibition, at one concentration (the size of the read-out at that concentration, not a potency): 20%
The estimate for compound 4 lay 7 percentage points above the measured number; low and high end bracket the measured number.
By their numbers in this assay, from the lowest: compounds 4 and 3 (each within the scatter of the next); then compounds 2 and 1 (each within the scatter of the next).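

In this assay, the first measured replacement of the nitro group gives a number 1 percentage points lower from compound 3 to compound 4 (within the scatter), so (ethoxycarbonyl)(methyl)amino, with 7 heavy atoms against 3 for nitro, leaves the number within the scatter at this place on the six-membered aromatic ring. The larger group has the same counts of hydrogen-bond donors and acceptors as nitro, so this pair does not test a change in those counts. No measurement on hand offers an explanation for this result.

As far as these compounds go, whether the same replacement would also leave the number within the scatter with ethoxy in place of dimethylamino remains open. Also open, from the compounds shown here alone, is whether a group of another kind here, such as a primary amine or a carboxylic acid, would move the number beyond the scatter.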